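Pyrimidine Thioether in Place of Methyltetrazole Thioether

The compounds below may be only part of what the source reports. "The series", "measured", "known", "first", "only" and "open" are said of these compounds alone.

Compound 1 `Cn1nnnc1SCC(=O)N/N=c1/scc(-c2ccc(Br)cc2)n1-c1ccccc1` has "not determined" (no result reported) in a functional assay on C6 cells (Rattus norvegicus) for cytotoxicity, read by MTT assay, with a stated time of 24 h (a higher number here means a weaker inhibitor, a lower number a stronger inhibitor), so where it stands on the numbers is not known. Its nearest measured relative, compound 2 `Cc1ccc(-c2cs/c(=N/NC(=O)CSc3nnnn3C)n2-c2ccccc2)cc1`, gives 36.3 ug/mL in this assay. Compound 3 `O=C(CSc1ncccn1)N/N=c1/scc(-c2ccc(Br)cc2)n1-c1ccccc1` is obtained from compound 1 by pyrimidin-2-yl in place of 1-methyl-1H-tetrazol-5-yl on a sulfur. With no number for compound 1, the size of this step cannot be read from any measured pair; the expectation is for no change beyond the usual scatter in either direction. Because compound 2 gives 36.3 ug/mL, compound 3 is expected to give about 30 ug/mL in this assay, within 10 ug/mL to 90 ug/mL.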

Compound 3, half-maximal inhibitory concentration: > 200 ug/mL
Compound 3 gave a limit, no number (the forecaster's own chance of this, stated with the estimate: 15%); middle value at least 6.6-fold (0.82 log units) from the limit.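

Among the compounds shown here, compound 1 has no number and compound 3 has only a limit in this assay, and no step between them can be read. The compounds shown leave open what pyrimidin-2-yl in place of 1-methyl-1H-tetrazol-5-yl does on its own.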